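Trifluoromethyl Piperazine Succinimides: Shortening the Chain

The source may report more compounds than this note shows. Statements on the series, on what has been measured and on what is new or still open speak of the compounds shown alone.

Compound 2: `CCC(C(=O)N1CCN(c2cccc(C(F)(F)F)c2)CC1)N1C(=O)CCC1=O`, 50%
Compound 1: `CC(C(=O)N1CCN(c2cccc(F)c2)CC1)N1C(=O)CCC1=O`, 0%

Of the compounds shown here, two have been measured in a functional assay on the whole organism (strain Swiss) with Mus musculus as the target, in the maximal electroshock model, with a stated time of 0.5 h, at a dose of 100 mg/kg by the intraperitoneal route; on this read-out lower numbers stand for a weaker effect and higher numbers for a stronger effect at the one dose given. Compound 2 gives 50%, the higher of the two numbers. Compound 1 gives 0%, which lies well below compound 2, beyond the usual scatter. For the measured compounds named here, compound 1 and compound 2 differ in more than one place, so no single step connects them, and only their two values can be compared.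

Compound 3, `CC(C(=O)N1CCN(c2cccc(C(F)(F)F)c2)CC1)N1C(=O)CCC1=O`, has not yet been measured in this assay. It differs from compound 2 in one place: hydrogen in place of methyl on a saturated chain carbon, two bonds along the chain from an amide-type nitrogen in a ring and a carbonyl carbon. Going by the values given here, no measured pair shows this change on its own, so the size of the step cannot be read from the data. The same methyl chain as in compound 3 is carried by compound 1, which gives 0%, and on that ground the step is expected to be downward. The expected step of a number 25 percentage points lower from compound 2 to compound 3 (beyond the scatter) is estimated to lie beyond the scatter. Compound 3 is expected to give 25%, within 0% to 60%.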

Compound 3, a percentage reported as activity, at one dose (the size of the read-out at that dose, not a potency): 75%
Beside the measured number, compound 3's estimate is 50 percentage points below it; measured number above the stated range.
By their numbers in this assay, from the lowest: compound 1; then compound 2; then compound 3.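

In this assay, hydrogen in place of methyl on a saturated chain carbon, two bonds along the chain from an amide-type nitrogen in a ring and a carbonyl carbon, gives a number 25 percentage points higher from compound 2 to compound 3 (beyond the scatter), so with trifluoromethyl held fixed, the change from ethyl to methyl goes with a stronger effect. With the methyl chain held fixed, trifluoromethyl in place of fluoro on an aromatic carbon gives a number 75 percentage points higher from compound 1 to compound 3 (beyond the scatter), which separates the effect of the aromatic group from that of the chain, something the earlier pair could not do. Nothing available accounts for either step.

From the compounds shown here alone, whether the chain step carries over to compounds with fluoro on the aromatic carbon stays open. Also open, going by these compounds, is how a propyl chain at the same carbon, or chloro on the aromatic carbon, would read in this assay at the one dose given.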